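The compounds below may be only part of what the source reports. "The series", "measured", "known", "first", "only" and "open" are said of these compounds alone.

Measured compounds:
Compound 1, `COc1ccc(CN2C(=O)C(=O)c3cc(/C=C/C(=O)OCCO)ccc32)cc1`; in a functional assay on K562 cells (Homo sapiens) for cytotoxicity, read by MTT assay, with a stated time of 48 h (on this read-out lower numbers stand for stronger inhibition and higher numbers for weaker inhibition), compound 1 gives 40 nM.
Compound 3, `COC(=O)/C=C/c1ccc2c(c1)C(=O)C(=O)N2Cc1ccccc1`; in this assay compound 3 gives 40 nM.
Compound 2, `CCCCc1ccc2c(c1)C(=O)C(=O)N2`; in this assay compound 2 reaches only > 10000 nM, which is the limit of > 10000 nM in this assay, at which 1 of the 3 values shown sits, a limit of the assay and not a number.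

Compound 1 stands level with compound 3 at the digits shown, the two within the usual scatter of each other. Compound 4, `CCCCOC(=O)/C=C/c1ccc2c(c1)C(=O)C(=O)N2Cc1ccc(OC)cc1`, differs from compound 1 in one place: ethyl in place of hydroxy on a saturated chain carbon, two bonds along the chain from an oxygen next to a carbonyl group. Going by the values given here, no pair among the measured compounds covers this kind of change, so the expectation rests on compound 1 alone. The step from compound 1 to compound 4 is expected to be no change at the digits printed from compound 1 to compound 4 (within the scatter), nothing beyond the scatter in either direction. Compound 4 is therefore estimated at 40 nM, with a range from 15 nM to 120 nM.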

Compound 4, half-maximal inhibitory concentration: 40 nM
The estimate for compound 4 equals the measured number at the digits printed; the range from low to high includes it.
By their numbers in this assay, from the lowest: compounds 1, 3 and 4 (each within the scatter of the next). At a limit, above all of these: compound 2.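

Swapping hydroxy for ethyl on this saturated chain carbon gives no change at the digits printed from compound 1 to compound 4 (within the scatter) in this assay and this is the first one-place change shown at this position. The hydroxy group, with its hydrogen-bond donor, is therefore not needed to keep this pair at its level in this assay, and the longer butoxy end is accepted as well. Nothing measured here bears on why the two compounds read alike.

On these data alone, whether an amine or a carboxylic acid at this chain end would hold that level remains open. So does the effect of a chain longer than butoxy.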